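This account rests on a few compounds, and the source may have more. Where it says the series, first, only, none or still open, it means among the compounds named here.

Working notes on the series. For the measured compounds named here, compound 2 `Cc1ccc(S(=O)(=O)c2cnc3ccc(Cl)cc3c2N2CCC(C)CC2)cc1Cl` stands lowest of the two numbers so far in an assay on isolated protein for displacement of a labelled ligand from metabotropic glutamate receptor 5 (Homo sapiens), with a stated time of 60 min, tested at 1 uM; a higher number here means more inhibition at the concentration tested (going by the name of the read-out), a lower number less inhibition: compound 2 gives 81%, while compound 1 `CC1CCN(c2c(S(=O)(=O)c3cccc(Cl)c3)cnc3ccc(Cl)cc23)CC1` gives 92%, the step being a number 11 percentage points lower from compound 1 to compound 2 (beyond the scatter). Compound 3 `Cc1cc(C)cc(S(=O)(=O)c2cnc3ccc(Cl)cc3c2N2CCC(C)CC2)c1` is next to be measured. Its change from compound 2 is 3,5-dimethylphenyl in place of 3-chloro-4-methylphenyl on a sulfonyl sulfur. Going by the values given here, the only measured step, a number 11 percentage points lower from compound 1 to compound 2 (beyond the scatter), concerns a single added methyl on that ring and bears on it only loosely; no step removes a chlorine. A step of about a number 3 percentage points lower from compound 2 to compound 3 (within the scatter) in this assay is therefore expected, with no clear direction beyond the scatter. Compound 3 is estimated at 78%, range 60% to 92%.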

Compound 3, a percentage reported as inhibition, at one concentration (the size of the read-out at that concentration, not a potency): 49%
Compound 3: middle estimate off by 29 percentage points, on the high side, and the stated range ends above it.
By their numbers in this assay, from the lowest: compound 3; then compound 2; then compound 1.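

The aryl group on the sulfonyl sulfur is far less forgiving in this assay than the single added methyl suggested: 3,5-dimethylphenyl gives a number 32 percentage points lower from compound 2 to compound 3 (beyond the scatter) and a number 43 percentage points lower from compound 1 to compound 3 (beyond the scatter). Compound 1 and compound 2, each with a chlorine on this ring, both stand above compound 3, although the entering and leaving groups of the step to compound 3 match in heavy-atom count. No measurement available here accounts for this drop.

Open, on these data alone, is whether the loss tracks the lost chlorine or the placement of the two methyl groups. Also open, as far as these compounds go, is how a methoxy, trifluoromethyl or primary amine on this ring would read in this assay.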